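The source may report more compounds than this note shows. Statements on the series, on what has been measured and on what is new or still open speak of the compounds shown alone.

Compound 1, `CC(C)n1ncc2c(C(=O)Nc3ccccc3F)cc(-c3cccnc3)nc21`, in an ADME assay on LLC-MK2 cells (Macaca mulatta) for cytotoxicity, read by spectrophotometry and crystal violet staining, with a stated time of 4 days (on this read-out higher numbers stand for lower toxicity in this test and lower numbers for higher toxicity in this test), gives 50000 nM.
Compound 2, `CC(C)n1ncc2c(C(=O)Nc3cccc(F)c3)cc(-c3cccs3)nc21`, in this assay gives only a limit of the assay, > 200000 nM.
Compound 3, `CC(C)n1ncc2c(C(=O)Nc3ccc(F)cc3)cc(-c3ccco3)nc21`, in this assay likewise gives only a limit of the assay, > 200000 nM.

The three measured compounds share one core and differ in the ring attached to it and in where a fluoro group sits on the phenyl of the amide. For compound 2 no number is known, only that it sits at the limit of > 200000 nM in this assay, at which 2 of the 3 values shown sit, so it cannot be ranked against compound 1, and it is one of two compounds at that limit. Compound 1 is the only one of the three with a number.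

The new compound, compound 4, `CC(C)n1ncc2c(C(=O)Nc3cccc(F)c3F)cc(-c3cccs3)nc21`, is built from compound 2 by a single change: fluoro in place of hydrogen on an aromatic carbon. The amide phenyl of compound 2 carries one fluoro group; in compound 4 a second fluoro group is added on an aromatic carbon of that same ring, ortho to the existing fluoro group and ortho to a large group. The thiophene ring and the rest of the core stay as they are.

For the measured compounds named here, no measured pair shows what such a change does in this assay. The only pattern is that all three measured compounds are weakly toxic or untoxic in this test, and compound 2 itself sits at the limit. The expectation is therefore a step from compound 2 to compound 4 of a number no higher from compound 2 to compound 4 (the limit leaves the size open), that is, none beyond the scatter. Compound 4 is expected to give about 200000 nM, with a range from 60000 nM to 200000 nM, and most likely to come back again as a limit rather than a number.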

Compound 4, half-maximal cytotoxic concentration: 75000 nM
Beside the measured number, compound 4's estimate is 2.7-fold (0.43 log units) above it; the range from low to high includes it.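

For the compounds shown here, compounds that differ in one place now exist for the first time, and in this assay the added fluoro group goes with an at least 2.6-fold lower number from compound 2 to compound 4 (0.42 log units; beyond the scatter). On this read-out a lower number means higher toxicity in the test, so a single extra fluorine on the amide phenyl, ortho to a fluoro group and ortho to a large group, is enough to bring the thiophene compound off the limit and into the range where a number can be read. The true size of the step remains unknown, since compound 2 gives only a limit of the assay, > 200000 nM, and the step is therefore a minimum: the limit of > 200000 nM in this assay, at which 2 of the 4 values shown sit.

The compounds shown do not tell why the number drops, or whether a chlorine atom, a methyl group or an amine on that same carbon would have a similar effect. Going by these compounds, it also remains open whether going from 3-fluorophenyl to 2,3-difluorophenyl would do the same with a ring other than thiophene on the shared core.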